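The compounds below may be only part of what the source reports. "The series", "measured", "known", "first", "only" and "open" are said of these compounds alone.

Measured compounds in this study:
Compound 1, `O=C(N/N=C/c1cccc(Cl)c1)c1cnccn1`: 100%
Compound 2, `O=C(N/N=C/c1ccc(Cl)cc1)c1cnccn1`: 56%
Compound 3, `O=C(N/N=C/c1ccccc1F)c1cnccn1`: 81%

All three share one core and differ only in the substituted benzene ring attached through the hydrazone. In an ADME assay on J774 cells (Mus musculus) for cytotoxicity, read by MTT assay, with a stated time of 48 h, tested at 150 ug/mL (on this read-out lower numbers stand for a stronger effect and higher numbers for a weaker effect at the one concentration tested), compound 2 gives 56%, the lowest of the three numbers. Its nearest neighbour is compound 3, whose value in this assay is 81%, higher by a margin beyond the usual scatter; furthest away is compound 1, which in this assay gives 100%, again beyond the scatter. On this read-out compound 2 thus shows the strongest effect among the three.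

The next compound, compound 4, `CCOc1ccc(/C=N/NC(=O)c2cnccn2)cc1`, has not yet been measured. It differs from compound 2 in one place: ethoxy in place of chloro on an aromatic carbon

For the measured compounds named here, no step between measured compounds changes that same position, so the data give no direct guide to the size of this move. With nothing comparable shown, a change no larger than the scatter, or a modest drift toward a weaker effect, seems the most reasonable expectation. Compound 4 is therefore expected to give about 75% in this assay, with a range from 50% to 100%. That estimate corresponds to an expected step of a number 19 percentage points higher from compound 2 to compound 4 (beyond the scatter) in this assay.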

Compound 4, a percentage reported as activity, at one concentration (the size of the read-out at that concentration, not a potency): 100%
For compound 4 the middle estimate is 25 percentage points below the measured one; the measured number falls inside the stated range.
By their numbers in this assay, from the lowest: compound 2; then compound 3; then compounds 1 and 4 (each within the scatter of the next).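

In this assay, replacing chloro with ethoxy on this aromatic carbon, para to a large group, gives a number 44 percentage points higher from compound 2 to compound 4 (beyond the scatter), so the stronger effect of compound 2 does not carry over to compound 4. For the compounds shown here, until this pair, no step between measured compounds had touched this position, and its sensitivity could not be judged; it now shows that the group carried here can shift the read-out by a large amount, in this case toward a weaker effect. Whether that shift reflects the loss of chloro or the arrival of ethoxy cannot be separated, and no evidence on hand bears on the reason for the step.

A single pair leaves open whether the weaker effect belongs to ethoxy alone or would also appear with other groups at this place, such as methoxy, an amine or a carboxylic acid. It also leaves open whether bromo would stay close to chloro, and how a longer chain in place of ethoxy would read in this assay.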